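The compounds below may be only part of what the source reports. "The series", "measured", "known", "first", "only" and "open" are said of these compounds alone.

Compounds measured so far and their values:

Compound 1 `CC1=C(N2CC2)C(=O)C(C(C)COC(N)=O)=C(N2CC2)C1=O` gives 5.71 in a functional assay on L1210 cells (Mus musculus), with a stated time of 12 days; on this read-out lower numbers stand for lower potency and higher numbers for higher potency (the scale is a negative logarithm).
Compound 2 `CC(C)C1=C(N2CC2)C(=O)C(C(C)C)=C(N2CC2)C1=O` gives 4.59.
Compound 3 `CCOC(COC(N)=O)C1=C(N2CC2)C(=O)C(C)=C(N2CC2)C1=O` gives 5.22.

Compound 1 stands highest of the three numbers; compound 3 comes nearest and compound 2 lies furthest below it. For the measured compounds named here, the one step that can be followed within the measured set runs from compound 1 to compound 3, where ethoxy takes the place of methyl on a saturated chain carbon bound to a double-bonded ring carbon and a saturated chain carbon, and the potency falls a number 0.49 log units lower from compound 1 to compound 3 (beyond the scatter). Compound 2, which carries two isopropyl groups on the shared core, shows a value well below both.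

Compound 4 `COC(CO)C1=C(N2CC2)C(=O)C(C)=C(N2CC2)C1=O` has not yet been measured. It differs from compound 1 in this way: a group of 5 heavy atoms (3 carbon, 2 oxygen; no ring) in place of a group of 7 heavy atoms (4 carbon, 1 nitrogen, 2 oxygen; no ring), on a double-bonded ring carbon. The side chain thus loses the carbamate and shortens, while a methoxy and a hydroxyl appear. The step from compound 1 to compound 3 suggests that altering this side chain lowers potency by a modest amount, and the larger change here is expected to cost somewhat more. For compound 4 the expected value is 5, with a range from 4.5 to 5.5, which would be a step of a number 0.71 log units lower from compound 1 to compound 4 (beyond the scatter).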

Compound 4, logarithm of the reciprocal of the active concentration, log(1/C): 5.75
The estimate for compound 4 lay 0.75 log units below the measured number, and the stated range ends below it.
By their numbers in this assay, from the lowest: compound 2; then compound 3; then compounds 1 and 4 (each within the scatter of the next).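

In this assay, the 2-hydroxy-1-methoxyethyl group of 5 heavy atoms on the double-bonded ring carbon does the work of the 7-heavy-atom carbamate side chain of compound 1, with a step of a number 0.04 log units higher from compound 1 to compound 4 (within the scatter). The carbamate is therefore not needed to keep this number, at least in the pair compared here, and the position accepts a smaller side chain that has the same counts of hydrogen-bond donors and acceptors. Changes at this side chain do not all cost potency, then: the only earlier step there was a number 0.49 log units lower from compound 1 to compound 3 (beyond the scatter), and it cannot be taken as a general penalty for altering the group, although the data given contain nothing that explains why the two changes differ.

The compounds shown leave open how the methoxy and the hydroxyl of compound 4 each bear on the number, since none differs from compound 4 in only one of these groups. They also leave open whether this position would keep its value with a primary amine or a carboxylic acid in place of the hydroxyl, or with a longer chain such as propoxy in place of the methoxy.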